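The source may report more compounds than this note shows. Statements on the series, on what has been measured and on what is new or still open speak of the compounds shown alone.

Results so far in a functional assay on HCT-116 cells (Homo sapiens) for cytotoxicity, read by MTT assay, with a stated time of 72 h (on this read-out lower numbers stand for stronger inhibition and higher numbers for weaker inhibition), for the tested compounds:
- compound 1 `Nc1cccc(Nc2c(C(=O)NCc3ccc(F)cc3)nc(Br)c3cccnc23)c1` gives > 10000 nM as a limit, not a number
- compound 2 `COc1cccc(CNC(=O)c2nc(Br)c3cccnc3c2N[C@H]2CC[C@H](N)CC2)c1` gives 6000 nM as a measured number
- compound 3 `N[C@H]1CC[C@H](Nc2c(C(=O)NCc3ccc(Cl)cc3Cl)nc(Br)c3cccnc23)CC1` gives 6000 nM as a measured number

Compound 1 stands at the limit of > 10000 nM in this assay, at which 1 of the 3 values shown sits, and so has no exact place on the scale.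

Compound 4 `O=C(NCc1ccc(F)cc1)c1nc(Br)c2cccnc2c1NCCO` keeps the core of compound 1 and changes one group. On a nitrogen on an aromatic ring, 2-hydroxyethyl takes the place of 3-aminophenyl, as counted here: 2-hydroxyethyl in place of 3-aminophenyl on a nitrogen on an aromatic ring and so the aromatic ring of that group leaves.

Among the measured compounds shown here, only one measured step is available, no change at the digits printed from compound 2 to compound 3 (within the scatter) and it lies at a different place in the molecule, so it says little about this change. For the measured compounds named here, no measured pair swaps the group on this nitrogen.

The expectation therefore starts from compound 1 at > 10000 nM which is a limit of the assay. The expected step of a number no higher from compound 1 to compound 4 (the limit leaves the size open) is no clear move beyond the scatter in either direction, and a limit rather than a number is also expected to be quite likely for compound 4 in this assay when it is tested. Compound 4 is expected at 10000 nM with 4000 nM to 30000 nM as the estimated range.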

Compound 4, half-maximal inhibitory concentration: > 20000 nM
Compound 4: a limit, no number (the forecaster's own chance of this, stated with the estimate: 60%); at least 2.0-fold (0.30 log units) between middle value and limit.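

In this assay, compound 1 and compound 4 each give a limit of the assay rather than a number, so the step between them cannot be read. The compounds shown leave open whether 2-hydroxyethyl in place of 3-aminophenyl on this nitrogen changes the result at all, and if so, in which direction.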